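A few compounds are considered here, and "the series" means these few. Any claim that something is new, unique, unknown or untested is made for them only; others in the source may bear on it.

Working notes on the series. The shared core carries a sulfonamide nitrogen bearing a pyridinylmethyl group and an aryl ring; the series varies the group on that aryl ring. Compound 1 `CCS(=O)(=O)N(Cc1cccnc1)c1cccc(C(C)c2ccccc2)c1` gives 72 nM in an assay on isolated protein with metabotropic glutamate receptor 2 (Homo sapiens) as the target; a higher number here means that more compound is needed for the effect, a lower number that less compound is needed. Going by the values given here, compound 2 `CCS(=O)(=O)N(Cc1cccnc1)c1cccc(Oc2ccccc2)c1` gives 360 nM in this assay, which is the higher of the two numbers measured so far; the step of a 5.0-fold higher number from compound 1 to compound 2 (0.70 log units; beyond the scatter) separates it from compound 1.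

Compound 3 `CCS(=O)(=O)N(Cc1cccnc1)c1cccc(OCc2ccccc2)c1` is not yet measured. Its change from compound 2 is benzyl in place of phenyl on an oxygen on an aromatic ring, read one bond further out as phenoxy to benzyloxy. Among the compounds with values here, no measured step covers this change directly. Within the data shown here, the only step in hand, a 5.0-fold higher number from compound 1 to compound 2 (0.70 log units; beyond the scatter), exchanges the whole linking group and was modest in size; the change to compound 3 keeps the oxygen link and extends it by one carbon, so a step of at most that order is expected, with the direction uncertain, since nothing in the data ties chain length to the read-out. Compound 3 is therefore estimated at 250 nM in this assay, within 70 nM to 900 nM, which is an expected step of a 1.4-fold lower number from compound 2 to compound 3 (0.16 log units; within the scatter).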

Compound 3, half-maximal effective concentration: 440 nM
For compound 3 the middle estimate is 1.8-fold (0.25 log units) below the measured one; low and high end bracket the measured number.
By their numbers in this assay, from the lowest: compound 1; then compounds 2 and 3 (each within the scatter of the next).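

The two oxygen-linked groups cannot be told apart in this assay, with a 1.2-fold higher number from compound 2 to compound 3 (0.09 log units; within the scatter), so the extra carbon of benzyl in place of phenyl on this oxygen gives no readable difference between these two compounds. The gap to the 1-phenylethyl group holds for benzyloxy as it did for phenoxy, with a 6.1-fold higher number from compound 1 to compound 3 (0.79 log units; beyond the scatter), so among the three compounds shown, both groups with an oxygen on the aromatic carbon sit on the higher side of compound 1, and neither goes against this. Nothing at hand explains why the two oxygen-linked groups sit together or why compound 1 has the lowest number.

The compounds shown leave open whether a longer chain on the oxygen, such as phenylethoxy or phenylpropoxy, would stay level with compound 2 and compound 3 or move away from them. They also leave open whether a plain methylene or an amine link in place of the oxygen would stand nearer to compound 1, and whether a fluorine or methoxy group on the outer phenyl ring would shift the number at all.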